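Substitution at the exocyclic nitrogen of the shared core

The source may report more compounds than this note shows. Statements on the series, on what has been measured and on what is new or still open speak of the compounds shown alone.

Compound 3 `Cc1ccc(-c2nc(NC(=O)c3ccccc3)c3cc(Cl)ccc3n2)cc1` gives 17.5 ug/mL in a functional assay on HepG2 cells (Homo sapiens) for antiproliferative activity, read by MTT assay, with a stated time of 48 h (on this read-out lower numbers stand for stronger inhibition and higher numbers for weaker inhibition), the second highest of the three numbers. Compound 1 `Cc1ccc(-c2nc(NO)c3cc(Cl)ccc3n2)cc1` gives 23.1 ug/mL and compound 2 `Cc1ccc(-c2nc(NN)c3cc(Cl)ccc3n2)cc1` gives 4.17 ug/mL. The step of a 1.3-fold lower number from compound 1 to compound 3 (0.12 log units; within the scatter) is within the scatter, whereas a 5.5-fold lower number from compound 1 to compound 2 (0.74 log units; beyond the scatter) and a 4.2-fold higher number from compound 2 to compound 3 (0.62 log units; beyond the scatter) are modest but beyond it. Compound 4 `Cc1ccc(-c2nc(NOC(=O)c3ccccc3)c3cc(Cl)ccc3n2)cc1` is not yet measured; the change is benzoyloxy in place of benzoyl on a nitrogen on an aromatic ring. Among the compounds with values here, the only measured step at this nitrogen that keeps the aryl carbonyl is a 1.3-fold lower number from compound 1 to compound 3 (0.12 log units; within the scatter), which was within the scatter; no measured step inserts an oxygen at this place. For compound 4 a step near the scatter is therefore expected, a 1.1-fold higher number from compound 3 to compound 4 (0.06 log units; within the scatter), with no firm direction. Compound 4 is estimated at 20 ug/mL, range 8 ug/mL to 50 ug/mL.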

Compound 4, half-maximal inhibitory concentration: 12.1 ug/mL
Estimate against measurement, compound 4: 1.7-fold (0.22 log units) above; the range from low to high includes it.
By their numbers in this assay, from the lowest: compound 2; then compounds 4, 3 and 1 (each within the scatter of the next).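

Placing an oxygen between the nitrogen and the benzoyl group does not separate benzoyloxy from benzoyl at this position (a 1.4-fold lower number from compound 3 to compound 4 (0.16 log units; within the scatter)). Benzoyl in place of hydrogen on the oxygen of compound 1 gives no separable change either (a 1.9-fold lower number from compound 1 to compound 4 (0.28 log units; within the scatter)). The amino compound remains apart from the new compound (a 2.9-fold higher number from compound 2 to compound 4 (0.46 log units; beyond the scatter)), so compound 2 alone stands clear of the other three.

Nothing available explains these differences. As far as these compounds go, whether a methylamino group, or an acetyl group in place of benzoyl, would come close to compound 2 stays open.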